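A few compounds are considered here, and "the series" means these few. Any claim that something is new, unique, unknown or untested is made for them only; others in the source may bear on it.

In a functional assay on G-361 cells (Homo sapiens) for antiproliferative activity, with a stated time of 72 h (on this read-out lower numbers stand for stronger inhibition and higher numbers for weaker inhibition), compound 3 (`Cc1ccc(CNc2ncnc3c2ncn3[C@@H]2O[C@H](CO)[C@@H](O)[C@H]2O)cc1`) has no standing of its own, as its entry reads "not determined" (no result reported). The only reference points are two limits. Compound 1 (`OC[C@H]1O[C@@H](n2cnc3c(NCc4ccc(Cl)cc4)ncnc32)[C@H](O)[C@@H]1O`) gives only a limit, > 166000 nM. Compound 2 (`OC[C@H]1O[C@@H](n2cnc3c(NCc4ccc(Br)cc4)ncnc32)[C@H](O)[C@@H]1O`) also gives only a limit, > 166000 nM.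

The next compound, compound 4 (`OC[C@H]1O[C@@H](n2cnc3c(NCc4ccc(Cl)cc4Cl)ncnc32)[C@H](O)[C@@H]1O`), differs from compound 3 as follows: 2,4-dichlorophenyl in place of 4-methylphenyl on a saturated chain carbon bound to a nitrogen on an aromatic ring. In words, 2,4-dichlorophenyl stands in place of 4-methylphenyl on a saturated chain carbon bound to a nitrogen on an aromatic ring.

Among the measured compounds shown here, only one measured step comes close to bearing on this change: a step that the two limits leave unreadable from compound 1 to compound 2, with bromo in place of chloro on an aromatic carbon. It offers no size to carry over, and with no number for compound 3, no direction can be stated for the step in this assay. For the measured compounds named here, the only guide is the limit of > 166000 nM in this assay, at which 2 of the 3 values shown sit, so compound 4 is expected to sit at or close to that limit, with a report of a limit alone the likeliest outcome. Compound 4 is estimated at 130000 nM, with an expected range from 40000 nM to 170000 nM.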

Compound 4, half-maximal inhibitory concentration: 128000 nM
Compound 4: the middle estimate sits 1.0-fold (0.01 log units) above what was measured; measured number inside the range.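

Among the compounds shown here, compound 4 gives the first number in this small set that is not a limit: in this assay, compound 4 reads 128000 nM. Chloro in place of hydrogen on an aromatic carbon gives an at least 1.2-fold lower number from compound 1 to compound 4 (0.11 log units; that floor lies within the scatter), and 2,4-dichlorophenyl in place of 4-bromophenyl gives an at least 1.2-fold lower number from compound 2 to compound 4 (0.11 log units; that floor lies within the scatter), so neither step shows a change that can be told from scatter. The measured number therefore adds little to the picture at this position, where the other readable values remain limits: the limit of > 166000 nM in this assay, at which 2 of the 4 values shown sit.

Going by these compounds, the step from compound 1 to compound 2 cannot be read, and compound 3 has no result, so the effect of 4-methylphenyl at this position stays unknown. On these data alone, what an amine or a carboxylic acid on the aromatic ring would give also remains open.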